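This account rests on a few compounds, and the source may have more. Where it says the series, first, only, none or still open, it means among the compounds named here.

Measured so far:
Compound 1 `O=C(O)Cc1sc(C(c2ccc(F)cc2)c2ccc(F)cc2)nc1-c1cc(F)cc(F)c1`: 340 nM
Compound 2 `O=C(O)Cc1sc(C(c2ccc(F)cc2)c2ccc(F)cc2)nc1-c1ccncc1`: 40 nM

Both compounds were tested in an in vitro functional assay on HEK285-7 cells for antagonist activity at prostaglandin D2 receptor 2 (Homo sapiens), read by BRET and beta-arrestin recruitment; a higher number here means a weaker inhibitor, a lower number a stronger inhibitor. Compound 2 gives the lowest of the two numbers, with compound 1 as its nearest neighbour; the step of an 8.5-fold lower number from compound 1 to compound 2 (0.93 log units; beyond the scatter) is beyond the scatter, so compound 2 is the stronger inhibitor of the pair.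

Compound 3 `O=C(O)Cc1sc(C(c2ccc(F)cc2)c2ccc(F)cc2)nc1-c1cc(F)nc(F)c1` differs from compound 2 in one place: 2,6-difluoropyridin-4-yl in place of pyridin-4-yl on an aromatic carbon. This change adds two fluorine atoms to the ring that compound 2 carries at that position.

For the measured compounds named here, only one measured step exists, and it bears on compound 3 only indirectly: from compound 1 to compound 2 a 3,5-difluorophenyl group was exchanged for pyridin-4-yl, a change that alters both the ring atom and the fluorine pattern at once. Going by the values given here, no measured pair shows what adding fluorine atoms to this ring alone does. The expectation for compound 3 is therefore a step of a 1.3-fold higher number from compound 2 to compound 3 (0.10 log units; within the scatter) that stays within or close to the scatter, with no clear direction. Compound 3 is estimated at 50 nM in this assay, within a range of 15 nM to 200 nM.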

Compound 3, half-maximal inhibitory concentration: 110 nM
Compound 3: the middle estimate sits 2.2-fold (0.34 log units) below what was measured; measured number inside the range.
By their numbers in this assay, from the lowest: compound 2; then compound 3; then compound 1.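

For the compounds shown here, with the pyridin-4-yl ring kept on the shared core, adding two fluorine atoms gives a 2.8-fold higher number from compound 2 to compound 3 (0.44 log units; beyond the scatter) in this assay, so fluorine alone, which no earlier pair isolated, makes a difference at this position on the five-membered aromatic ring. Keeping both fluorine atoms and exchanging 3,5-difluorophenyl for 2,6-difluoropyridin-4-yl gives a 3.1-fold lower number from compound 1 to compound 3 (0.49 log units; beyond the scatter) in this assay, so the ring nitrogen lowers the number even when fluorine is present, and the earlier exchange can now be read as two separate changes that each favour compound 2. Nothing available explains either step, so these results describe what happens at this position but not the reason for it.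

The compounds shown leave open whether a single fluorine atom on the pyridin-4-yl ring would give a number nearer that of compound 2 or that of compound 3. They also leave open how other small groups on this ring, such as a methyl group, a chlorine atom or an amine, would compare with fluorine.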